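Replacing the dichlorophenyl arm on a shared core

A few compounds are considered here, and "the series" means these few. Any claim that something is new, unique, unknown or untested is made for them only; others in the source may bear on it.

Measured so far in a functional assay on MIA PaCa-2 cells (Homo sapiens) for cytotoxicity, read by MTT assay, with a stated time of 72 h; on this read-out higher numbers stand for an effect only at larger amounts of compound and lower numbers for an effect already at smaller amounts:
compound 1 `COc1ccc(/C=C2\C(=O)N(c3c(Cl)cccc3Cl)c3ccccc32)cc1OC`: 5 ug/mL
compound 2 `O=C1/C(=C\c2c(Cl)cccc2Cl)c2ccccc2N1c1c(Cl)cccc1Cl`: > 100 ug/mL
compound 3 `O=C1/C(=C\c2cc3ccccc3nc2Cl)c2ccccc2N1c1c(Cl)cccc1Cl`: 5 ug/mL

The three measured compounds share one core and differ only in the aryl group on a double-bonded chain carbon bound to a double-bonded ring carbon. Compound 1 and compound 3 both sit at the same level in this assay, within the usual scatter of each other. Compound 2 stands apart: its value is a limit of the assay and not a number, (the limit of > 100 ug/mL in this assay, at which 1 of the 3 values shown sits), so only a boundary is known for it.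

Compound 4 `O=C1/C(=C\c2ccc(O)cc2)c2ccccc2N1c1c(Cl)cccc1Cl` is not yet measured. It differs from compound 2 by one exchange: 4-hydroxyphenyl in place of 2,6-dichlorophenyl on a double-bonded chain carbon bound to a double-bonded ring carbon. Since compound 1 and compound 3, each carrying a different aryl group at this place, give numbers well inside the measurable range, the exchange is expected to bring compound 4 back to a measurable effect. The estimated step from compound 2 to compound 4 is an at least 10-fold lower number from compound 2 to compound 4 (1.00 log units; beyond the scatter), a move toward stronger effect. Compound 4 is expected to give about 10 ug/mL, estimated between 3 ug/mL and 60 ug/mL.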

Compound 4, concentration for half-maximal effect: 2 ug/mL
For compound 4 the middle estimate is 5.0-fold (0.70 log units) above the measured one; the whole stated range lies above it.
By their numbers in this assay, from the lowest: compound 4; then compounds 1 and 3 (each within the scatter of the next). At a limit, above all of these: compound 2.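

In this assay, among the compounds shown here, 4-hydroxyphenyl in place of 2,6-dichlorophenyl gives an at least 50-fold lower number from compound 2 to compound 4 (1.69 log units; beyond the scatter), which is the only step that can be read between two compounds differing in one place. Compound 2 gives > 100 ug/mL, which is a limit and not a number, so the size of this step is known only as a bound: the limit of > 100 ug/mL in this assay, at which 1 of the 4 values shown sits.
Compound 4 gives 2 ug/mL, showing that on the shared core one exchange of the aryl group on a double-bonded chain carbon bound to a double-bonded ring carbon is enough to give a measured effect.

The compounds shown leave open whether the step follows from the chlorine atoms leaving or the hydroxyl group entering, as the two change together. They also do not tell how an unsubstituted phenyl ring would stand at this place, or an amine or a carboxylic acid in place of the hydroxyl group.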